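Replacing 3,4-dihydroxyphenyl with 2-hydroxyphenyl in compound 2

This account rests on a few compounds, and the source may have more. Where it says the series, first, only, none or still open, it means among the compounds named here.

In a physicochemical assay for solubility, using the shake flask method, with a stated time of 12 h (on this read-out lower numbers stand for lower solubility and higher numbers for higher solubility), compound 1 `O=C(/C=C/c1ccc(O)c(O)c1)CC(=O)/C=C/c1cccc(O)c1O` gives 3800 nM and compound 2 `O=C(/C=C/c1ccc(O)c(O)c1)CC(=O)/C=C/c1cc(O)ccc1O` gives 54000 nM. Within the data shown here, compound 2 therefore holds the higher of the only two numbers available. Compound 3 `O=C(/C=C/c1ccccc1O)CC(=O)/C=C/c1cc(O)ccc1O` is not yet measured. Its difference from compound 2 is 2-hydroxyphenyl in place of 3,4-dihydroxyphenyl on a double-bonded chain carbon bound to a double-bonded chain carbon; 2-hydroxyphenyl stands in place of 3,4-dihydroxyphenyl on a double-bonded chain carbon bound to a double-bonded chain carbon. Among the measured compounds shown here, the sole measured step is a 14-fold higher number from compound 1 to compound 2 (1.15 log units; beyond the scatter), which exchanges a different group, 2,5-dihydroxyphenyl in place of 2,3-dihydroxyphenyl. That step bears on size only and gives no direction for this change. A lower number is expected, since compound 2 at 54000 nM is the top of this small set, with a step somewhat smaller than the measured one. The expected step is a 4.5-fold lower number from compound 2 to compound 3 (0.65 log units; beyond the scatter). The estimate for compound 3 is 12000 nM, with a range of 2500 nM to 50000 nM.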

Compound 3, solubility: 4400 nM
The estimate for compound 3 lay 2.7-fold (0.44 log units) above the measured number; low and high end bracket the measured number.
By their numbers in this assay, from the lowest: compounds 1 and 3 (each within the scatter of the next); then compound 2.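

In this assay, the step of a 12-fold lower number from compound 2 to compound 3 (1.09 log units; beyond the scatter) shows that the read-out responds to the group at this second end of the molecule, not only to the 2,5-dihydroxyphenyl and 2,3-dihydroxyphenyl exchange in the step of a 14-fold higher number from compound 1 to compound 2 (1.15 log units; beyond the scatter). Both steps are large and beyond the scatter, so a change in the hydroxyl pattern of either aromatic ring can move the number substantially in these two pairs. Here, 2-hydroxyphenyl carries one hydrogen-bond donor and one acceptor against two of each in 3,4-dihydroxyphenyl, but nothing available accounts for the step.

A single exchange cannot separate the number of hydroxyl groups from their placement on the ring. Also open, as far as these compounds go, is how this read-out would respond to a phenyl group bearing an amine or a carboxylic acid at this place.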